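The compounds below may be only part of what the source reports. "The series", "measured", "known", "first", "only" and "open" are said of these compounds alone.

Measured in a functional assay on MCF7 cells (Homo sapiens) for antiproliferative activity, read by MTT assay, with a stated time of 72 h; on this read-out higher numbers stand for weaker inhibition of growth and lower numbers for stronger inhibition of growth:
Compound 1 `COc1ccc(Nc2nc3ncccc3n2Cc2ccccc2)cc1` gives 59100 nM.
Compound 2 `Cn1nc(-c2ccnc(Nc3ccc(O)cc3)n2)c2ccccc21` gives 8910 nM.

Of these two numbers, compound 2 holds the lower one, and the gap to compound 1 lies beyond the usual scatter, so compound 2 is the stronger inhibitor of growth here.

Compound 3 `Cn1nc(-c2ccnc(Nc3cccc(Cl)c3)n2)c2ccccc21` differs from compound 2 in one place: 3-chlorophenyl in place of 4-hydroxyphenyl on a nitrogen on an aromatic ring. Within the data shown here, no measured pair shows this change, so its effect cannot be read from the data. A modest step toward weaker inhibition is expected, roughly a 1.6-fold higher number from compound 2 to compound 3 (0.20 log units; within the scatter), but it could also fall within the scatter in either direction. Compound 3 is therefore estimated at 14000 nM, with a range from 3500 nM to 56000 nM.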

Compound 3, concentration for 50% growth inhibition: 5970 nM
Beside the measured number, compound 3's estimate is 2.3-fold (0.37 log units) above it; the range from low to high includes it.
By their numbers in this assay, from the lowest: compounds 3 and 2 (each within the scatter of the next); then compound 1.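

In this assay, 3-chlorophenyl in place of 4-hydroxyphenyl gives a 1.5-fold lower number from compound 2 to compound 3 (0.17 log units; within the scatter) on a nitrogen on an aromatic ring, so the two compounds cannot be told apart. For this one pair, the group at this position can carry a hydrogen-bond donor and acceptor or neither, and the readings stay within the scatter. No outside data help to explain this result.

Going by these compounds, whether a ring carrying an amine or a carboxylic acid would read the same remains open. So does whether 4-chlorophenyl would match 3-chlorophenyl.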